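This account rests on a few compounds, and the source may have more. Where it says the series, first, only, none or still open, it means among the compounds named here.

Three selenium-bearing carbamates have been tested in a functional assay on MCF7 cells (Homo sapiens) for cytotoxicity, read by MTT assay, with a stated time of 72 h; a higher number here means a weaker inhibitor of growth, a lower number a stronger inhibitor of growth. Compound 1 `N#C[Se]c1ccc(NC(=O)Oc2ccc(F)cc2)cc1` gives 8300 nM, compound 2 `CC(C)COC(=O)Nc1ccc([Se]C#N)cc1` gives 18100 nM, and compound 3 `C=CCOC(=O)Nc1ccc([Se][Se]c2ccc(NC(=O)OCC=C)cc2)cc1` gives 20800 nM. Compound 1 thus shows the lowest number of the three, and its gaps to compound 2 and to compound 3 both lie beyond the usual scatter. The unmeasured compound 4 `COc1ccc(OC(=O)Nc2ccc([Se]C#N)cc2)cc1` differs from compound 1 in one place: methoxy in place of fluoro on an aromatic carbon. For the measured compounds named here, no pair of measured compounds shows this exchange, so the size of its effect is unknown from the data. A small step is expected, none beyond the scatter, because compound 1 gives 8300 nM and the rest of the structure stays intact. The expected step is a 1.1-fold higher number from compound 1 to compound 4 (0.06 log units; within the scatter). Compound 4 is estimated at 9500 nM, with a range from 4000 nM to 22000 nM.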

Compound 4, concentration for 50% growth inhibition: 22400 nM
The estimate for compound 4 lay 2.4-fold (0.37 log units) below the measured number, and the stated range ends below it.
By their numbers in this assay, from the lowest: compound 1; then compounds 2, 3 and 4 (each within the scatter of the next).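

This position, on an aromatic carbon para to a large group, is not indifferent to a small exchange: in this assay, methoxy in place of fluoro gives a 2.7-fold higher number from compound 1 to compound 4 (0.43 log units; beyond the scatter) and this modest step lies beyond the scatter. The earlier compounds shown here differ from one another in more than one place, so they could not isolate the effect of this single group. Nothing available explains why growth inhibition weakens with this exchange.

As far as these compounds go, whether chloro, an amine or ethoxy at this position would behave like fluoro or like methoxy remains open. So does whether the same exchange would carry over to a carbamate with an alkyl chain in place of this aromatic ring.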